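Removing the methoxy group on the phenylbutyl chain

The source may report more compounds than this note shows. Statements on the series, on what has been measured and on what is new or still open speak of the compounds shown alone.

Measured compounds:
compound 1 `COc1ccc(CCCCCCCCOc2ccc(C[S+]([O-])Cc3cccc(C(=O)O)c3)nc2/C=C/C(=O)O)cc1` — 240 nM
compound 2 `O=C(O)/C=C/c1nc(CSCc2cccc(C(=O)O)c2)ccc1OCCCCCCCCc1ccccc1` — 15.4 nM
compound 3 `COc1ccc(CCCCOc2ccc(CSCc3cccc(C(=O)O)c3)nc2/C=C/C(=O)O)cc1` — 9.2 nM

In an assay on isolated protein for displacement of a labelled ligand from leukotriene B4 receptor 1 (Homo sapiens) (on this read-out higher numbers stand for weaker inhibition and lower numbers for stronger inhibition), compound 3 gives the lowest of the three numbers; compound 2 lies within the scatter of it, and compound 1 stands well above both. Compound 4 `O=C(O)/C=C/c1nc(CSCc2cccc(C(=O)O)c2)ccc1OCCCCc1ccccc1` differs from compound 3 by hydrogen in place of methoxy on an aromatic carbon. Among the compounds with values here, no measured step isolates this change. Within the data shown here, the only step on the chain end, a 1.7-fold lower number from compound 2 to compound 3 (0.22 log units; within the scatter), combined a shorter chain with the arrival of the methoxy group and stayed within the scatter, so the methoxy group alone is unlikely to carry a large effect. Compound 4 is therefore expected to give 13 nM (range 5 nM to 35 nM), a step of a 1.4-fold higher number from compound 3 to compound 4 (0.15 log units; within the scatter) that is expected to stay within the scatter.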

Compound 4, inhibition constant: 4.8 nM
The estimate for compound 4 lay 2.7-fold (0.43 log units) above the measured number, outside the stated range (below it).
By their numbers in this assay, from the lowest: compounds 4, 3 and 2 (each within the scatter of the next, the first and the last beyond it); then compound 1.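

On the aromatic carbon para to a large group, hydrogen in place of methoxy gives a 1.9-fold lower number from compound 3 to compound 4 (0.28 log units; within the scatter), so this position gives up the methoxy group without a change beyond the scatter. Phenyl in place of 4-phenylbutyl gives a 3.2-fold lower number from compound 2 to compound 4 (0.51 log units; beyond the scatter), the first step at the chain end to pass the scatter. No measurement shown accounts for either step.

Going by these compounds, whether a hydroxy group or a fluorine atom on that aromatic carbon would read the same stays open. On these data alone, whether a methoxy group on the longer chain of compound 2 would act alike also stays open.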